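Fluoro in Place of Methyl on the Sulfonamide Ring

The compounds below may be only part of what the source reports. "The series", "measured", "known", "first", "only" and "open" are said of these compounds alone.

Compound 1 `O=c1cc(Cn2cc(CCCO)nn2)c2ccc(O)cc2o1` carries a short alcohol chain on the triazole; in a functional assay on HepG2 cells (Homo sapiens) for inhibition, read by MTT assay, with a stated time of 72 h (on this read-out higher numbers stand for weaker inhibition and lower numbers for stronger inhibition), compound 1 gives only a limit of > 100000 nM, not a number. Compound 2 `Cc1ccc(S(=O)(=O)NCc2cn(Cc3cc(=O)oc4cc(O)ccc34)nn2)cc1` carries instead a (4-methylphenyl)sulfonyl amide, and in this assay compound 2 gives 29800 nM, the only actual number among the two results shown, the other being (the limit of > 100000 nM in this assay, at which 1 of the 2 values shown sits). Compound 3 `O=c1cc(Cn2cc(CNS(=O)(=O)c3ccc(F)cc3)nn2)c2ccc(O)cc2o1` differs from compound 2 in one place: fluoro in place of methyl on an aromatic carbon, para to a large group. Among the compounds with values here, no measured pair shows what such a swap does here, so in this assay the step is expected to stay within the usual scatter, with no clear direction. Compound 3 is therefore estimated at 30000 nM, within the range 12000 nM to 80000 nM. This estimate means a step of a 1.0-fold higher number from compound 2 to compound 3 (0.00 log units; within the scatter).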

Compound 3, half-maximal inhibitory concentration: 76700 nM
For compound 3 the middle estimate is 2.6-fold (0.41 log units) below the measured one; measured number inside the range.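

In this assay the change of methyl to fluoro, on an aromatic carbon para to a large group, gives a 2.6-fold higher number from compound 2 to compound 3 (0.41 log units; beyond the scatter), so inhibition becomes weaker by a modest step that lies beyond the scatter. Within the data shown here, this is the only measured pair for this position, and it shows that the read-out responds here even when one heavy atom simply takes the place of another on the (4-methylphenyl)sulfonyl group. The data shown give no explanation for this step.

With only methyl and fluoro to compare at this position, a single step cannot show a trend. From the compounds shown here alone, how chloro, methoxy or an amine would read at the same place remains open, as does whether the same swap would give a similar step on a different side chain.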